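Swapping the amide cap of an alkyne thiazole series

A few compounds are considered here, and "the series" means these few. Any claim that something is new, unique, unknown or untested is made for them only; others in the source may bear on it.

Compound 1 `CC(=O)N1CCc2nc(C#Cc3ccccc3)sc2C1` and compound 2 `Cc1cccc(C(=O)N2CCc3nc(C#Cc4ccccc4)sc3C2)n1` share a core and differ only at the carbonyl carbon. In an assay on HEK293 cells for negative allosteric modulation of metabotropic glutamate receptor 5 (Homo sapiens), read by FLIPR, with a stated time of 1 h (on this read-out lower numbers stand for stronger inhibition and higher numbers for weaker inhibition), compound 1 gives 90 nM. For compound 2 this assay reports only a limit, > 10000 nM. The change an at least 110-fold higher number from compound 1 to compound 2 (2.04 log units; beyond the scatter) shows how strongly this cap matters, with compound 2 sitting at the limit of > 10000 nM in this assay, at which 1 of the 2 values shown sits. Going by these compounds, compound 3 `O=C(N1CCC(F)CC1)N1CCc2nc(C#Cc3ccccc3)sc2C1` is untested; it differs from compound 2 by 4-fluoropiperidin-1-yl in place of 6-methylpyridin-2-yl on a carbonyl carbon. Since the cap choice moved potency so far before, a sizable step downward is expected, an at least 16-fold lower number from compound 2 to compound 3 (1.22 log units; beyond the scatter). Compound 3 is therefore estimated at 600 nM, within 60 nM to 8000 nM.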

Compound 3, half-maximal inhibitory concentration: > 10000 nM
Compound 3 was reported as a limit (the forecaster's own chance of this, stated with the estimate: 25%); middle value at least 16-fold (1.22 log units) from the limit.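

Placing the non-aromatic 4-fluoropiperidin-1-yl on the carbonyl carbon, in place of the aromatic 6-methylpyridin-2-yl, does not restore activity in this assay, so the loss is not confined to one ring cap. Against the methyl cap of the core of compound 1, the new group gives an at least 110-fold higher number from compound 1 to compound 3 (2.04 log units; beyond the scatter). The step between compound 2 and compound 3 cannot be read, and both ring caps now end at the same limit: the limit of > 10000 nM in this assay, at which 2 of the 3 values shown sit.

Going by these compounds, it remains open whether a small chain such as ethyl keeps the activity of compound 1. Also open, on these data alone, is whether a ring-free amine such as dimethylamino on the carbonyl carbon would do so.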